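The compounds below may be only part of what the source reports. "The series", "measured", "known", "first", "only" and "open" are said of these compounds alone.

Measured compounds:
compound 1, `CCn1c(=O)ccn(C2OC(Cn3cc(COC(=O)Cn4cnc5c4c(=O)n(C)c(=O)n5C)nn3)C(OC)C2OC)c1=O`, 2670 nM
compound 2, `CCn1c(=O)ccn(C2OC(Cn3cc(COC(=O)Cn4cnc5c4c(=O)n(C)c(=O)n5C)nn3)C(O)C2O)c1=O`, 1890 nM
compound 3, `Cn1c(=O)c2c(ncn2CC(=O)NCC(=O)OCc2cn(CC3OC(n4ccc(=O)[nH]c4=O)C4OC(C)(C)OC34)nn2)n(C)c1=O`, 12600 nM

The three compounds were tested in a functional assay on MCF7 cells (Homo sapiens) for cytotoxicity, read by MTT assay, with a stated time of 48 h; on this read-out higher numbers stand for weaker inhibition and lower numbers for stronger inhibition. Compound 2 gives the smallest number of the set, yet the value of compound 1 lies within the usual scatter of it, so these two cannot be told apart on the numbers shown. Among the measured compounds shown here, compound 3 stands clearly apart: its value lies beyond the scatter from compound 2, and it is the only compound of the three for which that holds.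

Compound 4, `CCn1c(=O)ccn(C2OC(Cn3cc(COC(=O)C(C)n4cnc5c4c(=O)n(C)c(=O)n5C)nn3)C(O)C2O)c1=O`, has not yet been measured. It differs from compound 2 in one place: methyl in place of hydrogen on a saturated chain carbon bound to an aromatic nitrogen and a carbonyl carbon.

For the measured compounds named here, no measured pair in this set differs by such a change, so the size of this step has no precedent here. Going by the values given here, a single methyl entering for a hydrogen on that saturated chain carbon is the smallest change one can make, and nothing among the measured compounds points in either direction for it. Compound 4 is therefore expected to come out close to compound 2, with the step of a 1.1-fold higher number from compound 2 to compound 4 (0.02 log units; within the scatter) expected to lie within the scatter. In this assay compound 4 is estimated at 2000 nM, with a range from 900 nM to 4500 nM.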

Compound 4, half-maximal inhibitory concentration: 2130 nM
Compound 4: the middle estimate sits 1.1-fold (0.03 log units) below what was measured; the range from low to high includes it.
By their numbers in this assay, from the lowest: compounds 2, 4 and 1 (each within the scatter of the next); then compound 3.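

In this assay, the change gives a 1.1-fold higher number from compound 2 to compound 4 (0.05 log units; within the scatter), so on the numbers shown, methyl in place of hydrogen on this saturated chain carbon, bound to an aromatic nitrogen and a carbonyl carbon, cannot be told apart from the parent compound. Among the compounds shown here, compound 2 and compound 4 form the first pair in the set that differs only at this position, so the earlier compounds gave no direct reading of a change here, whereas this pair shows that one added carbon at this place is tolerated in this cell read-out. Nothing among the data shown explains this outcome, so it stands as an observation only.

A single methyl leaves open how this carbon would respond to a larger or different group, such as an ethyl, a phenyl, an amine or a carboxylic acid, for which the compounds shown offer no reading. As far as these compounds go, it also remains open whether methyl at this carbon would read the same way on the background of compound 1 or of compound 3, since neither has a partner that differs from it in this one place.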